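Series notes: compound 3, 4-fluorophenyl for isopropyl

The compounds below may be only part of what the source reports. "The series", "measured", "known", "first", "only" and "open" are said of these compounds alone.

Among the compounds with values here, compound 2 `COc1ccc(F)cc1CNCCCNc1ccnc2cc(CC(C)C)ccc12` gives 2900 nM in an ADME assay on HepG2 cells (Homo sapiens) for cytotoxicity, read by luminescence, CellTiter-Glo and ATP content, with a stated time of 72 h (on this read-out lower numbers stand for an effect already at smaller amounts and higher numbers for an effect only at larger amounts of compound), the lowest of the two numbers measured so far. Within the data shown here, compound 1 `COc1ccc(Oc2ccc3c(NCCCNCc4cc(F)ccc4OC)ccnc3c2)cc1` sits higher in this assay at 7000 nM; the one measured step, a 2.4-fold lower number from compound 1 to compound 2 (0.38 log units; beyond the scatter), is modest and rests on isobutyl in place of 4-methoxyphenoxy on an aromatic carbon.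

Compound 3 `COc1ccc(F)cc1CNCCCNc1ccnc2cc(Cc3ccc(F)cc3)ccc12` differs from compound 2 in one place: 4-fluorophenyl in place of isopropyl on a saturated chain carbon bound to an aromatic carbon. Cut one bond further out the change reads isobutyl to 4-fluorobenzyl, so an aromatic ring returns to the group on the aromatic carbon that carried 4-methoxyphenoxy in compound 1, now joined through a saturated chain carbon. The step from compound 1 to compound 2 is the only one that bears on this, and it moved the number only modestly; a change of similar or smaller size in this assay is expected, most likely toward a somewhat higher number, with no change beyond the scatter also possible. For compound 3 the estimate is 4000 nM, range 1500 nM to 11000 nM, corresponding to an expected step of a 1.4-fold higher number from compound 2 to compound 3 (0.14 log units; within the scatter).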

Compound 3, half-maximal effective concentration in the HepG2 assay: 3530 nM
For compound 3 the middle estimate is 1.1-fold (0.05 log units) above the measured one, within the range that was stated.
By their numbers in the HepG2 assay, from the lowest: compounds 2, 3 and 1 (each within the scatter of the next, the first and the last beyond it).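

In the HepG2 assay, 4-fluorophenyl in place of isopropyl on a saturated chain carbon bound to an aromatic carbon gives a 1.2-fold higher number from compound 2 to compound 3 (0.09 log units; within the scatter), so this place accepts one six-membered aromatic ring of carbon only, with 7 heavy atoms entering for 3, without a step beyond the scatter. Read from the other side, going from 4-methoxyphenoxy to 4-fluorobenzyl gives a 2.0-fold lower number from compound 1 to compound 3 (0.30 log units; within the scatter), so that pair is not separated, whereas isobutyl in place of 4-methoxyphenoxy gave a 2.4-fold lower number from compound 1 to compound 2 (0.38 log units; beyond the scatter). In a physicochemical assay for acid dissociation, compound 2 gives 9.47 and compound 3 gives 9.47, which is no change at the digits printed from compound 2 to compound 3 (within the scatter); nothing at hand accounts for any of these steps.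

From the compounds shown here alone, whether a group of another kind on this aromatic carbon, such as an amine, a carboxylic acid or a longer chain, would give a number beyond the scatter of compound 2 in the HepG2 assay stays open. Also open, going by these compounds, is whether plain benzyl, without the fluorine, would read like 4-fluorobenzyl in the HepG2 assay and in the physicochemical assay.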